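The compounds below may be only part of what the source reports. "The series", "measured", "known", "first", "only" and "open" are said of these compounds alone.

Measured in a functional assay on HepG2 cells (Homo sapiens) for cytotoxicity, read by MTT assay, with a stated time of 48 h; a higher number here means a weaker inhibitor, a lower number a stronger inhibitor:
compound 1 `CCCCCCCCCCCCCCNC(=O)[C@@H](NC(=O)c1nccc2ccccc12)[C@@H](C)O`, 28600 nM
compound 2 `CCCCCCCCCCCCCCNC(=O)[C@@H](NC(=O)c1cc2ccccc2n1C)[C@@H](C)O`, 34500 nM

Compound 2 stands at the upper of the two numbers; its nearest neighbour is compound 1, and the step of a 1.2-fold higher number from compound 1 to compound 2 (0.08 log units; within the scatter) lies within the scatter, so the two are not separated. Compound 3 `CCCCCCCCCCCCCCNC(=O)[C@@H](NC(=O)/C=C/c1ccccc1)[C@@H](C)O` carries 2-phenylethenyl in place of 1-methyl-1H-indol-2-yl on a carbonyl carbon. For the measured compounds named here, only one measured step bears on an exchange at this carbonyl carbon, and it stayed within the scatter, so in this assay no step beyond the scatter is expected in either direction. The expected step is a 1.2-fold lower number from compound 2 to compound 3 (0.06 log units; within the scatter). Compound 3 is estimated at 30000 nM, within 12000 nM to 80000 nM.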

Compound 3, half-maximal inhibitory concentration: 150000 nM
For compound 3 the middle estimate is 5.0-fold (0.70 log units) below the measured one, outside the stated range (above it).
By their numbers in this assay, from the lowest: compounds 1 and 2 (each within the scatter of the next); then compound 3.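

At the carbonyl carbon on the amide-type nitrogen, the group can move the number in this assay: 2-phenylethenyl in place of 1-methyl-1H-indol-2-yl gives a 4.3-fold higher number from compound 2 to compound 3 (0.64 log units; beyond the scatter) and in place of isoquinolin-1-yl gives a 5.2-fold higher number from compound 1 to compound 3 (0.72 log units; beyond the scatter). The exchange seen earlier at this carbon therefore does not hold for every group. No measurement at hand accounts for this step.

Open, from the compounds shown here alone, is whether the double bond outside aromatic rings or the loss of the second ring matters more. Going by these compounds, a plain phenyl or an amine-bearing group at this carbon also remains untested here.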